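From 4-methoxyphenyl to 3-methoxyphenyl: compound 3 to compound 4

The compounds below may be only part of what the source reports. "The series", "measured", "known", "first", "only" and "open" are said of these compounds alone.

Values in a functional assay on BGC-823 cells (Homo sapiens) for antiproliferative activity, read by MTT assay, with a stated time of 48 h; a lower number here means a stronger inhibitor, a higher number a weaker inhibitor:
- compound 1 `CCn1cc(-c2nc3ccc([N+](=O)[O-])cc3o2)c(=O)c2cc(F)c(N3CCNC(C)C3)c(F)c21`: 2740 nM
- compound 2 `CCn1cc(-c2ccc(Cl)cc2)c(=O)c2cc(F)c(N3CCNCC3)cc21`: 14600 nM
- compound 3 `CCn1cc(-c2ccc(OC)cc2)c(=O)c2cc(F)c(N3CCNCC3)cc21`: 46100 nM

Of these three, compound 3 has the highest number, 46100 nM, which makes it the weakest inhibitor. Compound 4 `CCn1cc(-c2cccc(OC)c2)c(=O)c2cc(F)c(N3CCNCC3)cc21` has the same atoms, joined differently: 3-methoxyphenyl in place of 4-methoxyphenyl on an aromatic carbon. Among the measured compounds shown here, only one measured step bears on this change, and only loosely: a 3.2-fold higher number from compound 2 to compound 3 (0.50 log units; beyond the scatter). For the measured compounds named here, that step swaps one group for another, and no measured pair shows a methoxy group changing place. A step no larger than that one is therefore expected in this assay, leaning slightly towards a lower number. The estimate means a 1.3-fold lower number from compound 3 to compound 4 (0.12 log units; within the scatter). For compound 4 the expected value is 35000 nM, with an estimated range of 13000 nM to 90000 nM.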

Compound 4, half-maximal inhibitory concentration: 14700 nM
Beside the measured number, compound 4's estimate is 2.4-fold (0.38 log units) above it, within the range that was stated.
By their numbers in this assay, from the lowest: compound 1; then compounds 2 and 4 (each within the scatter of the next); then compound 3.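

In this assay, moving the methoxy group alone, with no atom gained or lost, gives a 3.1-fold lower number from compound 3 to compound 4 (0.50 log units; beyond the scatter), so on this phenyl ring the place of a group counts, not only which group it is. Replacing 4-chlorophenyl with 3-methoxyphenyl gives a 1.0-fold higher number from compound 2 to compound 4 (0.00 log units; within the scatter), so these two groups cannot be told apart here. Nothing available explains why the place of the methoxy group matters. On these data alone, whether a chloro group responds in the same way when it changes place stays open. So does the effect of an amine or a carboxylic acid on this phenyl ring.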